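Cyano for bromo on two cores of one sulfonamide series

The compounds below may be only part of what the source reports. "The series", "measured", "known", "first", "only" and "open" are said of these compounds alone.

The measured compounds and their values:
compound 1, `Cc1cc(S(N)(=O)=O)ccc1NC(=O)COc1ccc2ccccc2c1C(=O)c1cc(Cl)cc(Br)c1`, 36600 nM
compound 2, `Cc1cc(S(N)(=O)=O)ccc1NC(=O)COc1ccc2ccccc2c1C(=O)c1cc(Cl)cc(C#N)c1`, 49400 nM
compound 3, `Cc1cccc(C(=O)c2c(OCC(=O)Nc3ccc(S(N)(=O)=O)cc3C)ccc3cc(Br)ccc23)c1`, 6800 nM

In an ADME assay on C8166 cells (Homo sapiens) for cytotoxicity, read by colorimetric assay and MTT assay (a higher number here means that more compound is tolerated, a lower number that less compound is tolerated), compound 1 gives 36600 nM. Compound 2 differs from compound 1 in one place, (cyano in place of bromo on an aromatic carbon), and this step, a 1.3-fold higher number from compound 1 to compound 2 (0.13 log units; within the scatter), is within the scatter, so the two values show no order between them. Compound 3 gives 6800 nM in this assay, the lowest of the three numbers, beyond the scatter from both compound 1 and compound 2. The difference between the core of compound 1 and the core of compound 3 is not broken down here.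

Compound 4, `Cc1cccc(C(=O)c2c(OCC(=O)Nc3ccc(S(N)(=O)=O)cc3C)ccc3cc(C#N)ccc23)c1`, has not yet been measured in this assay. It differs from compound 3 by cyano in place of bromo on an aromatic carbon. For the measured compounds named here, this is the same kind of change as the one from compound 1 to compound 2, but the surroundings differ: in compound 1 the bromo sits on a six-membered aromatic ring of carbon only, meta to a chloro group and meta to a large group, whereas in compound 3 it sits on such a ring that is part of a fused or bridged system of two rings, meta to a fused ring and para to a fused ring.

Because the earlier step of a 1.3-fold higher number from compound 1 to compound 2 (0.13 log units; within the scatter) stayed within the scatter, a step of similar small size is expected for compound 4, namely a 1.2-fold higher number from compound 3 to compound 4 (0.07 log units; within the scatter). Compound 4 is therefore estimated at 8000 nM in this assay, with a range from 3500 nM to 18000 nM.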

Compound 4, half-maximal cytotoxic concentration: 15200 nM
Compound 4: middle estimate off by 1.9-fold (0.28 log units), on the low side; the measured number falls inside the stated range.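

On the second core of the series, in this assay, cyano in place of bromo gives a 2.2-fold higher number from compound 3 to compound 4 (0.35 log units; beyond the scatter), a modest step, whereas the same change on the core of compound 1 stayed within the scatter. Set side by side, the two steps cannot be told apart, so the change carries from one core to the other with no measurable difference in size: the same change on two cores in this assay, a 1.3-fold higher number (0.13 log units; within the scatter) from compound 1 to compound 2 and a 2.2-fold higher number (0.35 log units; beyond the scatter) from compound 3 to compound 4, 1.7-fold (0.22 log units) apart, within the scatter of two such steps. For the compounds shown here, this does not show that the change has the same size on both cores, or that it would give a higher number on any other core, as the comparison rests on a single pair of compounds per core and only one of the two steps lies beyond the scatter.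

The compounds shown leave open how either core would respond to other groups at this place, such as an amine or a carboxylic acid, as only bromo and cyano are compared here. They also leave open whether the step would keep its size on a third core, and what part of the gap between the core of compound 1 and the core of compound 3 comes from which structural difference.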